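Bis(trifluoromethyl)benzenesulfonamides Tested for Pancreatic Cell Growth Inhibition

A few compounds are considered here, and "the series" means these few. Any claim that something is new, unique, unknown or untested is made for them only; others in the source may bear on it.

Of the compounds shown here, two have been measured in a functional assay on ASPC1 cells (Homo sapiens) for inhibition, read by MTT assay, with a stated time of 72 h; on this read-out higher numbers stand for weaker inhibition of growth and lower numbers for stronger inhibition of growth. Compound 1 `CC(C)(C)c1ccc(CNCCNS(=O)(=O)c2cc(C(F)(F)F)cc(C(F)(F)F)c2)cc1` gives 14000 nM. Compound 2 `O=S(=O)(NCCCNCc1ccc(Cl)cc1)c1cc(C(F)(F)F)cc(C(F)(F)F)c1` gives 3000 nM, the lowest of the two numbers, and its distance to compound 1 lies beyond the scatter. Compound 3 `COc1cccc(CNCCCNS(=O)(=O)c2cc(C(F)(F)F)cc(C(F)(F)F)c2)c1` is not yet measured; it differs from compound 2 by 3-methoxyphenyl in place of 4-chlorophenyl on a saturated chain carbon bound to an amine nitrogen. Within the data shown here, no step between measured compounds shows this change, so the size of the step is uncertain; a small weakening is expected, a 1.7-fold higher number from compound 2 to compound 3 (0.22 log units; within the scatter). For compound 3 a value of 5000 nM is estimated, within 1500 nM to 16000 nM.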

Compound 3, concentration for 50% growth inhibition: 3800 nM
Beside the measured number, compound 3's estimate is 1.3-fold (0.12 log units) above it, within the range that was stated.
By their numbers in this assay, from the lowest: compounds 2 and 3 (each within the scatter of the next); then compound 1.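

In this assay the exchange gives a 1.3-fold higher number from compound 2 to compound 3 (0.10 log units; within the scatter), so compounds with 4-chlorophenyl and 3-methoxyphenyl at this place, on a saturated chain carbon bound to an amine nitrogen, stand within the scatter of each other. Among these compounds, this is the first single-place step at this position, which the earlier pair of compounds could not provide. Nothing measured here accounts for the result.

Open, from the compounds shown here alone, is whether a carboxylic acid or a nitrile on the phenyl group would stay within the scatter. Also open, going by these compounds, is how a longer chain would read with either group.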